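Chain lengthening at the aromatic amine: cytotoxicity notes

The source may hold more compounds than are shown below. What is called first, only, known or untested is meant among the compounds shown, and "the series" means these compounds.

Measured so far:
compound 1 `CCCCCNc1cnc(C(=O)NCc2ccccc2)cn1` — > 100000 nM
compound 2 `CCCCCCCNc1cnc(C(=O)NCc2ccccc2)cn1` — > 100000 nM
compound 3 `CCCCNc1cnc(C(=O)NCc2ccccc2)cn1` — 100000 nM

Among the compounds with values here, in an ADME assay on MDCK cells (Canis lupus familiaris) for cytotoxicity, read by microscopy, with a stated time of 6 days (on this read-out higher numbers stand for lower toxicity in this test and lower numbers for higher toxicity in this test), compound 3 gives 100000 nM, the only actual number in the set. Compound 1 gives a value that is a limit of the assay, > 100000 nM. Compound 2 likewise gives a limit, > 100000 nM. Two of the three values therefore sit at the limit of > 100000 nM in this assay, at which 2 of the 3 values shown sit, and only compound 3 falls onto the readable scale.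

Compound 4 `CCCCCCCCNc1cnc(C(=O)NCc2ccccc2)cn1` differs from compound 3 by butyl in place of hydrogen on a saturated chain carbon, four bonds along the chain from a nitrogen on an aromatic ring. The measured steps that bear on it run the other way: a number no higher from compound 1 to compound 3 (the limit leaves the size open) and a number no higher from compound 2 to compound 3 (the limit leaves the size open), both of a size the limits leave open, while a step that the two limits leave unreadable from compound 1 to compound 2 cannot be read at all. Taken in reverse, adding chain length on this carbon has never lowered the minimum cytotoxic concentration below where compound 3 stands, and the two longer chains both returned limits.

Compound 4 is therefore expected to sit at or beyond the same limit, with no change at the digits printed from compound 3 to compound 4 (within the scatter) as the estimated step, most likely reported as a limit rather than a number. The estimate for compound 4 is 100000 nM, within 50000 nM to 200000 nM.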

Compound 4, minimum cytotoxic concentration: >= 20000 nM
Compound 4 was reported as a limit; the forecaster's own chance of this, stated with the estimate: 70%; the middle value does not contradict the limit.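

In this assay compound 4 gives >= 20000 nM, which is a limit of the assay and not a number. No new step can be read from it: the steps to compound 4 from compound 1, compound 2 and compound 3 all stay unreadable. The compounds shown leave open whether chain length changes the minimum cytotoxic concentration at all.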